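This account rests on a few compounds, and the source may have more. Where it says the series, first, only, none or still open, it means among the compounds named here.

Values in an ADME assay on L929 cells (Mus musculus) for cytotoxicity, read by resazurin assay, with a stated time of 48 h (a higher number here means that more compound is tolerated, a lower number that less compound is tolerated), for the three measured compounds:
Compound 1 `NC(=O)CCCn1c2ccc([N+](=O)[O-])cc2c(=O)n1Cc1ccccc1`: > 256000 nM as a limit
Compound 2 `CN(C)C(=O)CCCn1c2ccc([N+](=O)[O-])cc2c(=O)n1Cc1ccccc1`: > 256000 nM as a limit
Compound 3 `CCOCCCn1c2ccc([N+](=O)[O-])cc2c(=O)n1Cc1ccccc1`: 170000 nM as a number

Within the data shown here, compound 3 stands at 170000 nM in this assay as the only true number of the three. Compound 4 `CC(=O)n1c2ccc([N+](=O)[O-])cc2c(=O)n1Cc1ccccc1` has not been measured. It carries acetyl in place of 3-ethoxypropyl on an aromatic nitrogen and otherwise keeps the structure of compound 3.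

Among the measured compounds shown here, two measured steps change the end of the chain on that nitrogen: an at least 1.5-fold lower number from compound 1 to compound 3 (0.17 log units; that floor lies within the scatter) and an at least 1.5-fold lower number from compound 2 to compound 3 (0.17 log units; that floor lies within the scatter) are the only sized steps available. The third, a step that the two limits leave unreadable from compound 1 to compound 2, gives no size. The two sized steps remain floors due to the limit of > 256000 nM in this assay, at which 2 of the 3 values shown sit, and neither replaces the whole chain or introduces acetyl, so they bear on the change only loosely.

With compound 3 at 170000 nM as the anchor, no step beyond the scatter is expected in this assay and no direction can be called. The expected step is a 1.1-fold lower number from compound 3 to compound 4 (0.05 log units; within the scatter) in this reading. Compound 4 is estimated at 150000 nM with a range of 40000 nM to 256000 nM as its expected span.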

Compound 4, concentration lethal to 50% of the cells: > 256000 nM
Compound 4 was reported as a limit; the forecaster's own chance of this, stated with the estimate: 30%; middle value at least 1.7-fold (0.23 log units) away from the limit.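

In this assay, among these compounds, compound 4 also reads only as a limit, so a limit on this aromatic nitrogen is not tied to the carbamoyl or dimethylcarbamoyl chain ends of the earlier compounds, and the short acetyl group reaches it too, with compound 3 as the one compound that goes against this. Acetyl in place of 3-ethoxypropyl gives an at least 1.5-fold higher number from compound 3 to compound 4 (0.17 log units; that floor lies within the scatter), so the change can be given only as a floor, and the true step may be larger but cannot be told apart from the scatter on this evidence. The steps to compound 4 from compound 1 and from compound 2 cannot be read, due to the shared limit: the limit of > 256000 nM in this assay, at which 3 of the 4 values shown sit.

Among the compounds shown here, compound 3, at 170000 nM, remains the only true number in this assay, so how far the other three lie from it is unknown. From the compounds shown here alone, what stays open is whether an amine, a carboxylic acid or a longer chain on this aromatic nitrogen would give a number or another limit, and whether a group other than benzyl on the neighbouring ring atom would change the picture.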